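The source may hold more compounds than are shown below. What is called first, only, known or untested is meant among the compounds shown, and "the series" means these compounds.

Measured so far in a physicochemical assay for lipophilicity, read by HPLC, in phosphate buffer, measured as octanol-water partition, at pH 7.4, tested at 100 uM (on this read-out higher numbers stand for higher lipophilicity and lower numbers for lower lipophilicity), for the series
- compound 1 `CCOc1cc(C)c(-c2cccc(CNc3ccc(OCC(=O)O)cc3)c2)c(C)c1` gives "not determined" (no result reported)
- compound 2 `Cc1cc(OCCCS(C)(=O)=O)cc(C)c1-c1cccc(CNc2ccc(OCC(=O)O)c(F)c2)c1` gives 1.73
- compound 3 `O=C(O)COc1ccc(NCc2cccc(-c3ccccc3Cl)c2)cc1F` gives 2.71

Compound 3 stands highest of the two numbers, and compound 2 lies lower, beyond the scatter. Compound 4 `Cc1cc(O)ccc1-c1cccc(CNc2ccc(OCC(=O)O)c(F)c2)c1`, not yet measured, carries 4-hydroxy-2-methylphenyl in place of 2-chlorophenyl on an aromatic carbon and otherwise matches compound 3. Among the measured compounds shown here, no measured pair covers this exchange, so the expectation remains uncertain. A downward step in this assay beyond the scatter is expected, with compound 2 at 1.73 as the lower reference. The estimated change is a number 0.81 log units lower from compound 3 to compound 4 (beyond the scatter) on this basis. For compound 4 the expected value is 1.9 (expected range 1.5 to 2.3).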

Compound 4, distribution coefficient: 1.85
Estimate against measurement, compound 4: 0.05 log units above; measured number inside the range.
By their numbers in this assay, from the lowest: compounds 2 and 4 (each within the scatter of the next); then compound 3.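

In this assay, among the compounds shown here, 4-hydroxy-2-methylphenyl in place of 2-chlorophenyl on this aromatic carbon gives the first step that can be read at a single place (a number 0.86 log units lower from compound 3 to compound 4 (beyond the scatter)). The read-out therefore responds to an exchange of the aryl group at this position, meta to a large group. No measurement shown bears on what lies behind the step.

Still open, from the compounds shown here alone, is how the step divides between the hydroxy and the methyl of the entering group. Also open, going by these compounds, is how an amine or a nitrile on this aromatic carbon would read in this assay here.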